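The source may hold more compounds than are shown below. What is called first, only, known or untested is meant among the compounds shown, and "the series" means these compounds.

Three compounds have so far been measured in an ADME assay on MT4 cells (Homo sapiens) for cytotoxicity; a higher number here means that more compound is tolerated, a lower number that less compound is tolerated:

Compound 1 `CCCCCCCCc1cc(-c2cn([C@H]3C[C@H](O)[C@@H](CO)O3)c(=O)[nH]c2=O)on1`: 3000 nM
Compound 2 `CCCc1cc(-c2cn([C@H]3C[C@H](OC(C)=O)[C@@H](COC(C)=O)O3)c(=O)[nH]c2=O)on1`: 3000 nM
Compound 3 `CC(C)(C)c1ccc(-c2cc(-c3cn([C@H]4C[C@H](O)[C@@H](CO)O4)c(=O)[nH]c3=O)on2)cc1`: 3000 nM

On these numbers compound 2 stands level with compound 1 and with compound 3; the three values lie within the usual scatter of one another, so none of them can be called better or worse tolerated than the others.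

Compound 4 `CC(=O)OC[C@H]1O[C@@H](n2cc(-c3cc(-c4ccc(C(C)C)cc4)no3)c(=O)[nH]c2=O)C[C@@H]1OC(C)=O` has not yet been measured. It differs from compound 2 in one place: 4-isopropylphenyl in place of propyl on an aromatic carbon. The change exchanges a short chain for a substituted phenyl ring on the shared core.

Going by the values given here, one measured step bears on this. It is of the same kind, a chain on the same aromatic carbon replaced by a substituted phenyl ring, and it gave no change at the digits printed from compound 1 to compound 3 (within the scatter). Among the compounds with values here, that step is the only guide available; nothing in the three measured compounds suggests that swapping a chain for a ring at this position moves the read-out.

Compound 4 is therefore expected to behave like compound 2, with no change at the digits printed from compound 2 to compound 4 (within the scatter), a step that is not expected to exceed the scatter. The estimate for compound 4 is 3000 nM, with a range from 1500 nM to 6000 nM.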

Compound 4, half-maximal cytotoxic concentration: 3000 nM
Compound 4: the middle estimate sits on the measured number at the digits printed; the measured number falls inside the stated range.
By their numbers in this assay, from the lowest: compounds 1, 2, 3 and 4 (each within the scatter of the next).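

In this assay the swap of propyl for 4-isopropylphenyl gave no change at the digits printed from compound 2 to compound 4 (within the scatter) and so added a second case of a chain giving way to a substituted phenyl ring on this aromatic carbon, alongside no change at the digits printed from compound 1 to compound 3 (within the scatter) in the earlier pair. The new step shows that this kind of change leaves the read-out unmoved in compounds carrying two acetyl ester groups as well as in compounds carrying free hydroxyl groups at those places, and that it does so when a group of 3 heavy atoms with no ring gives way to one of 9 heavy atoms with a six-membered aromatic ring. Nothing offered here gives a reason for this flat result.

Every group shown at this position is built of carbon only, with no hydrogen-bond donors or acceptors and no net charge, so the picture covers just that narrow kind of substituent. As far as these compounds go, how the read-out would respond to an amine, a carboxylic acid or a pyridine ring on this aromatic carbon remains open.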